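From methyl to fluoro on the shared core

The source may report more compounds than this note shows. Statements on the series, on what has been measured and on what is new or still open speak of the compounds shown alone.

compound 1 `Cc1ccc(S(=O)(=O)Cc2ncn(C)c2[N+](=O)[O-])cc1`: > 846000 nM
compound 2 `Cn1cnc(CS(=O)(=O)c2ccc(Br)cc2)c1[N+](=O)[O-]`: > 694000 nM

In an ADME assay on THP-1 cells (Homo sapiens) for cytotoxicity, read by flow cytometry and propidium iodide staining, with a stated time of 72 h (on this read-out lower numbers stand for stronger inhibition and higher numbers for weaker inhibition), compound 1 gives > 846000 nM as a limit of the assay and not as a number. Compound 2 gives > 694000 nM as a limit as well, so neither value shown is a number. Compound 3 `Cn1cnc(CS(=O)(=O)c2ccc(F)cc2)c1[N+](=O)[O-]` is not yet measured and differs from compound 1 by fluoro in place of methyl on an aromatic carbon in one place only. Among the compounds with values here, the single measured change at that place, bromo in place of methyl on an aromatic carbon, is a step that the two limits leave unreadable from compound 1 to compound 2 and offers no size to carry over, so no step beyond the scatter is expected in this assay for fluoro. The expected change is a number no higher from compound 1 to compound 3 (the limit leaves the size open) in this estimate. Compound 3 is estimated at 840000 nM with an expected range from 450000 nM to 1300000 nM and is likely to be reported as a limit too.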

Compound 3, half-maximal inhibitory concentration: > 835000 nM
Compound 3 gave a limit, no number; the forecaster's own chance of this, stated with the estimate: 90%; the middle value is on the limit's open side.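

In this assay, within the data shown here, compound 1, compound 2 and compound 3 all stand as limits and not as numbers, so no step among them can be read. The compounds shown leave open whether methyl, bromo and fluoro differ at all on this read-out, and at what concentration any of them would reach half-maximal inhibition.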